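Replacing an azetidinyl carbonyl with a methylurea

This account rests on a few compounds, and the source may have more. Where it says the series, first, only, none or still open, it means among the compounds named here.

Going by the values given here, the three compounds measured so far share one core and differ only in the group on the piperidine nitrogen. Compound 1 `CC(=O)N1CCC(NS(=O)(=O)c2ccc(NC(=O)c3ccccc3C)c3ccccc23)CC1` carries an acetyl group and gives 6.7 nM in an assay on L1.2 cells for binding affinity to C-C chemokine receptor type 8 (Homo sapiens); a lower number here means a stronger inhibitor, a higher number a weaker inhibitor. Compound 2 `Cc1ccccc1C(=O)Nc1ccc(S(=O)(=O)NC2CCN(C(=O)CO)CC2)c2ccccc12` carries a hydroxyacetyl group and gives 5.4 nM in this assay; the step of a 1.2-fold lower number from compound 1 to compound 2 (0.09 log units; within the scatter) stays within the scatter. Compound 3 `Cc1ccccc1C(=O)Nc1ccc(S(=O)(=O)NC2CCN(C(=O)C3CNC3)CC2)c2ccccc12` carries an azetidin-3-yl carbonyl group and gives 1.5 nM in this assay, the lowest of the three numbers; it is reached by a 4.5-fold lower number from compound 1 to compound 3 (0.65 log units; beyond the scatter) and by a 3.6-fold lower number from compound 2 to compound 3 (0.56 log units; beyond the scatter), both beyond the scatter.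

Compound 4 `CNC(=O)N1CCC(NS(=O)(=O)c2ccc(NC(=O)c3ccccc3C)c3ccccc23)CC1` takes the step (methylamino in place of azetidin-3-yl on a carbonyl carbon). Among the compounds with values here, the steps that bear on it are those into compound 3: each time the azetidin-3-yl group arrived, the number fell modestly, so its departure is expected to send the number back up by a modest amount. Compound 4 is therefore expected to give 5.5 nM in this assay, with a range from 2 nM to 15 nM, which means an estimated step of a 3.7-fold higher number from compound 3 to compound 4 (0.56 log units; beyond the scatter). Such a number would lie back near those of compounds 1 and 2.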

Compound 4, inhibition constant: 0.7 nM
Beside the measured number, compound 4's estimate is 7.9-fold (0.90 log units) above it, outside the stated range (below it).
By their numbers in this assay, from the lowest: compound 4; then compound 3; then compounds 2 and 1 (each within the scatter of the next).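

In this assay the azetidin-3-yl group turns out not to be needed for a low number on this carbonyl carbon: methylamino, which has no ring and 2 heavy atoms against 4, gives a 2.1-fold lower number from compound 3 to compound 4 (0.33 log units; beyond the scatter), so the ring is not what sets the floor here. The same group also stands well clear of the two simpler groups, with a 7.7-fold lower number from compound 2 to compound 4 (0.89 log units; beyond the scatter) and a 9.6-fold lower number from compound 1 to compound 4 (0.98 log units; beyond the scatter), which makes compound 4 the strongest of the four and shows that this position has more range than the small step between methyl and hydroxymethyl suggested. Nothing available explains this order of the groups.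

The compounds shown do not separate the part played by the nitrogen of methylamino from that of its methyl, so a plain amino group, dimethylamino or ethylamino on the same carbonyl carbon would be the direct test. They also leave open whether methoxy, with oxygen in place of that nitrogen, would keep the number this low, and whether the step holds on any other core.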